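This account rests on a few compounds, and the source may have more. Where it says the series, first, only, none or still open, it means among the compounds named here.

For the measured compounds named here, compound 2 `NC(=O)c1c(NC(=O)c2ccccc2Cl)sc2c1CCN(C(=S)Nc1cccc3ccccc13)C2` gives 20700 nM in a functional assay on MKN-74 cells (Homo sapiens) for antiproliferative activity, with a stated time of 24 h (a higher number here means a weaker inhibitor, a lower number a stronger inhibitor), the highest of the two numbers measured so far. Compound 1 `NC(=O)c1c(NC(=O)c2ccccc2Cl)sc2c1CCN(Cc1ccc(Cl)cc1Cl)C2` gives 16300 nM in this assay, and the gap between these two compounds lies within the scatter, so neither can be called stronger or weaker. Compound 3 `COc1ccccc1NC(=S)N1CCc2c(sc(NC(=O)c3ccccc3Cl)c2C(N)=O)C1` has not yet been measured. It differs from compound 2 in one place: 2-methoxyphenyl in place of naphthalen-1-yl on an amide-type nitrogen. Going by the values given here, no comparable step between measured compounds is known; the step expected here is a 1.0-fold lower number from compound 2 to compound 3 (0.01 log units; within the scatter), nothing beyond the scatter. Compound 3 is therefore estimated at 20000 nM, with a range from 7000 nM to 55000 nM.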

Compound 3, half-maximal inhibitory concentration: 35200 nM
For compound 3 the middle estimate is 1.8-fold (0.25 log units) below the measured one; low and high end bracket the measured number.
By their numbers in this assay, from the lowest: compounds 1, 2 and 3 (each within the scatter of the next, the first and the last beyond it).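

On the amide-type nitrogen, 2-methoxyphenyl in place of naphthalen-1-yl gives a 1.7-fold higher number from compound 2 to compound 3 (0.23 log units; within the scatter), so one aromatic ring carrying a methoxy group cannot be told apart from two fused rings in this assay. For the compounds shown here, changing the whole group on the amine nitrogen in the ring gives a 2.2-fold higher number from compound 1 to compound 3 (0.33 log units; beyond the scatter), the first step here beyond the scatter, though a modest one. No supporting measurement bears on these numbers. From the compounds shown here alone, whether a plain phenyl or a 4-aminophenyl on the amide-type nitrogen would give a clearly lower number remains open.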